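Taking the tert-butoxycarbonyl group off compound 1

The source may report more compounds than this note shows. Statements on the series, on what has been measured and on what is new or still open speak of the compounds shown alone.

In a functional assay on L1210 cells (Mus musculus) for inhibition, with a stated time of 48 h (on this read-out lower numbers stand for stronger inhibition and higher numbers for weaker inhibition), compound 1 `COC(=O)C[C@H](NC(=O)OC(C)(C)C)C(=O)N(Cc1ccccc1)C1(C(=O)NCc2ccccc2)CCN(Cc2ccccc2)CC1` gives 18000 nM. Compound 2 `COC(=O)C[C@H](NC(=O)OC(C)(C)C)C(=O)N(C1CC1)C1(C(=O)NCc2ccccc2)CCN(Cc2ccccc2)CC1`, which carries cyclopropyl in place of benzyl on an amide-type nitrogen, gives 14000 nM. That step, a 1.3-fold lower number from compound 1 to compound 2 (0.11 log units; within the scatter), shows that the two cannot be told apart. Compound 3 `COC(=O)C[C@H](NC(=O)OC(C)(C)C)C(=O)N(Cc1ccccc1)C1(C(=O)NCc2ccccc2)CCNCC1` gives only a limit of the assay, > 200000 nM. Its loss of the benzyl on the ring amine nitrogen is a large step, an at least 11-fold higher number from compound 1 to compound 3 (1.04 log units; beyond the scatter).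

Compound 4 `COC(=O)C[C@H](N)C(=O)N(Cc1ccccc1)C1(C(=O)NCc2ccccc2)CCN(Cc2ccccc2)CC1` differs from compound 1 at one place: hydrogen in place of tert-butoxycarbonyl on an amine nitrogen. In words, hydrogen stands in place of tert-butoxycarbonyl on an amine nitrogen. Going by the values given here, no measured step makes this exact change. The nearest guide is an at least 11-fold higher number from compound 1 to compound 3 (1.04 log units; beyond the scatter), which also leaves a hydrogen on a nitrogen, but at another place in the molecule. A rise in the number is therefore likely, though a smaller one than that. In this assay the expected step is a 2.5-fold higher number from compound 1 to compound 4 (0.40 log units; beyond the scatter). The estimate for compound 4 is 45000 nM, within an expected range of 12000 nM to 200000 nM.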

Compound 4, half-maximal inhibitory concentration: 90000 nM
Beside the measured number, compound 4's estimate is 2.0-fold (0.30 log units) below it; low and high end bracket the measured number.
By their numbers in this assay, from the lowest: compounds 2 and 1 (each within the scatter of the next); then compound 4. At a limit, above all of these: compound 3.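

The tert-butoxycarbonyl on this amine nitrogen matters to the read-out: in this assay, swapping (tert-butoxycarbonyl)amino for amino gives a 5.0-fold higher number from compound 1 to compound 4 (0.70 log units; beyond the scatter), a modest step but one that clearly exceeds the noise. Until now, the only changes shown were on the amide-type nitrogen and the ring amine nitrogen, so this is the first evidence that this end of the molecule also counts, and that the group cannot be removed without a cost. Nothing shown explains why removing it raises the number.

From the compounds shown here alone, it remains open whether the whole tert-butoxycarbonyl is needed, or whether a smaller acetyl or a larger benzyloxycarbonyl on the same nitrogen would keep the number close to that of compound 1. Going by these compounds, the effect of a methyl or an ethyl on this nitrogen also remains unknown.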